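Efficacy notes: methoxy removal from compound 2

This account rests on a few compounds, and the source may have more. Where it says the series, first, only, none or still open, it means among the compounds named here.

Measured so far:
compound 1, `c1cncc(N2CCCNCCC2)c1`: 78%
compound 2, `COc1cc(N2CCNCC2)cnc1Br`: 68%

Two compounds have been run in an assay on HEK293 cells with Neuronal acetylcholine receptor; alpha4/beta2 (Homo sapiens) as the target, read by FLIPR and calcium flux; on this read-out higher numbers stand for larger maximal responses and lower numbers for smaller maximal responses. Compound 1 gives 78%, and compound 2 gives 68%, which is the lower of the two numbers, but the gap to compound 1 lies within the scatter of repeated measurements, so the two values are read as the same. Going by the values given here, no pair of measured compounds differs in a single place, so no measured step is available to guide the next change.

Compound 3, `Brc1ccc(N2CCNCC2)cn1`, is the untested compound. It departs from compound 2 in one place: hydrogen in place of methoxy on an aromatic carbon. Among the compounds with values here, nothing among the measured compounds speaks to what the methoxy contributes to maximal response, so no direction is indicated for this change. The step from compound 2 to compound 3 is therefore expected to be no change at the digits printed from compound 2 to compound 3 (within the scatter), that is, none beyond the scatter. On this basis compound 3 is estimated to reach 68% in this assay, with a range from 50% to 85%.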

Compound 3, largest response reached (reported as efficacy), in percent of the reference or control that the assay uses: 129%
Compound 3: middle estimate off by 61 percentage points, on the low side, and the stated range ends below it.
By their numbers in this assay, from the lowest: compounds 2 and 1 (each within the scatter of the next); then compound 3.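

In this assay, going by these compounds alone, the change of methoxy to hydrogen on the aromatic carbon ortho to the bromo group, two atoms from the ring nitrogen, gives a large step of a number 61 percentage points higher from compound 2 to compound 3 (beyond the scatter) and so provides the first single-place comparison. Maximal response therefore depends strongly on what occupies this one position, a sensitivity that the two earlier values could not reveal, and of this matched pair the methoxy form is the one with the smaller response. The direction and size of the step are established, but no measurement at hand bears on why it occurs.

Still open, on these data alone, is whether the step reflects the loss of methoxy in particular or would be matched by other replacements on this carbon, and a fluoro, a methyl, an ethoxy or an amino group there would help to separate these readings. Also open, as far as these compounds go, is whether the bromo group takes part in the result, which a chloro group or hydrogen in its place would address, and whether the same change carries over to other cores such as the core of compound 1.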